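The source may hold more compounds than are shown below. What is called first, only, known or untested is meant among the compounds shown, and "the series" means these compounds.

Working notes on the step to compound 4 `Nc1c(F)c(=O)[nH]c(=O)n1[C@@H]1O[C@H](CO)[C@@H](O)[C@H]1O`. In a functional assay on OVCAR-4 cells (Homo sapiens) for antiproliferative activity, read by WST assay, with a stated time of 3 days (a higher number here means a weaker inhibitor, a lower number a stronger inhibitor), compound 3 `O=c1[nH]c(=O)n([C@@H]2O[C@H](CO)[C@@H](O)[C@H]2O)c(I)c1F` gives > 50000 nM, which is a limit and not a number. Compound 1 `O=c1cc(I)n([C@@H]2O[C@H](CO)[C@@H](O)[C@H]2O)c(=O)[nH]1` gives > 50000 nM, also a limit. Compound 2 `Nc1cc(=O)[nH]c(=O)n1[C@@H]1O[C@H](CO)[C@@H](O)[C@H]1O` gives > 50000 nM, again a limit. For the measured compounds named here, the series so far stands at the limit of > 50000 nM in this assay, at which 3 of the 3 values shown sit, so compound 3 has no measured position of its own.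

Compound 4 keeps the fluoro group of compound 3 and carries amino in place of iodo on an aromatic carbon, next to the ring nitrogen: amino in place of iodo on an aromatic carbon. The same exchange appears in a step that the two limits leave unreadable from compound 1 to compound 2, and the fluoro change appears in a step that the two limits leave unreadable from compound 1 to compound 3. Neither step has a readable size, so neither supplies a number to carry over. Going by the values given here, with no active compound among the three, no measurable gain is expected in this assay, though this expectation rests on limits alone. The expected change is a number no higher from compound 3 to compound 4 (the limit leaves the size open). For compound 4 the estimate is 50000 nM, with an expected range of 15000 nM to 100000 nM.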

Compound 4, half-maximal inhibitory concentration: 2000 nM
Estimate against measurement, compound 4: 25-fold (1.40 log units) above; the whole stated range lies above it.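

In this assay, amino next to the ring nitrogen has a readable effect when a fluoro group stands ortho to it: the exchange of iodo for amino gives an at least 25-fold lower number from compound 3 to compound 4 (1.39 log units; beyond the scatter). The fluoro group matters at its own place too, with amino kept: fluoro in place of hydrogen gives an at least 25-fold lower number from compound 2 to compound 4 (1.39 log units; beyond the scatter). The steps from compound 1 cannot be read, and only compound 4, with amino and fluoro together, stands off the limit: the limit of > 50000 nM in this assay, at which 3 of the 4 values shown sit.

As far as these compounds go, how much each group adds on its own remains open, as compounds 1, 2 and 3 give limits and not numbers. From the compounds shown here alone, it is also open whether a methylamino group in place of amino, or a chloro group in place of fluoro, would keep the activity of compound 4.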